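Notes on the step to compound 4

The compounds below may be only part of what the source reports. "The series", "measured", "known", "first", "only" and "open" are said of these compounds alone.

Compound 1 `CN(C)CCCCCn1c2c(c3ccccc31)C(=O)c1c[n+]([O-])c3ccccc3c1C2=O` gives 470 nM in a functional assay on HCT-116 cells (Homo sapiens) for cytotoxicity, read by MTT assay, with a stated time of 72 h; on this read-out lower numbers stand for stronger inhibition and higher numbers for weaker inhibition
Compound 2 `O=C1c2c[n+]([O-])c3ccccc3c2C(=O)c2c1c1ccccc1n2CCCCN1CCNCC1` gives 700 nM in this assay
Compound 3 `O=C1c2c[n+]([O-])c3ccccc3c2C(=O)c2c1c1ccccc1n2Cc1cn([C@@H]2O[C@H](CO)[C@@H](O)[C@H](O)[C@H]2O)nn1` gives 130 nM in this assay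

Compound 3 has the lowest of the three numbers, and its gaps to compound 1 and compound 2 both lie beyond the scatter. Compound 4 `O=C1c2c[n+]([O-])c3ccccc3c2C(=O)c2c1c1ccccc1n2Cc1cn(C[C@@H](O)CO)nn1` differs from it by one change: 2,3-dihydroxypropyl in place of 3,4,5-trihydroxy-6-(hydroxymethyl)oxan-2-yl on an aromatic nitrogen and here 2,3-dihydroxypropyl stands in place of 3,4,5-trihydroxy-6-(hydroxymethyl)oxan-2-yl on an aromatic nitrogen. Going by the values given here, the only measured step is a 1.5-fold higher number from compound 1 to compound 2 (0.17 log units; within the scatter) and it lies on a saturated chain, so it does not test this group directly. Its small size gives only weak support for a limited change. A moderate rise is expected in this assay since compound 3 at 130 nM sits lowest of the three, but the direction remains uncertain. The expected step is a 1.7-fold higher number from compound 3 to compound 4 (0.23 log units; within the scatter) and this is only an estimate. In this assay the estimated value for compound 4 is 220 nM with an expected range from 90 nM to 550 nM as a working figure.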

Compound 4, half-maximal inhibitory concentration: 190 nM
The estimate for compound 4 lay 1.2-fold (0.06 log units) above the measured number; low and high end bracket the measured number.
By their numbers in this assay, from the lowest: compounds 3 and 4 (each within the scatter of the next); then compounds 1 and 2 (each within the scatter of the next).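

In this assay the change on the aromatic nitrogen gives a 1.5-fold higher number from compound 3 to compound 4 (0.16 log units; within the scatter), so the low number of compound 3 does not depend on the six-membered non-aromatic ring of the 3,4,5-trihydroxy-6-(hydroxymethyl)oxan-2-yl group. The smaller 2,3-dihydroxypropyl group also keeps the separation from the amine-ending chains, with a 3.7-fold lower number from compound 2 to compound 4 (0.57 log units; beyond the scatter) and a 2.5-fold lower number from compound 1 to compound 4 (0.39 log units; beyond the scatter); each of these steps replaces the whole side chain, so the triazole and its substituent cannot be assigned separate shares. No available evidence bears on the cause of these differences.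

From the compounds shown here alone, whether the hydroxyl groups contribute remains open, and a plain propyl chain on the same aromatic nitrogen would address that. A carboxylic acid or an amine at this position is also untested among the compounds shown.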